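The compounds below may be only part of what the source reports. "The series", "measured", "known", "first", "only" and "open" are said of these compounds alone.

Of the compounds shown here, three sharing one core have so far been measured in a functional assay on the whole organism for antagonist activity, with Mus musculus as the target (a lower number here means that less compound is needed, a higher number that more compound is needed for the effect), and compound 2 (`CCC(=O)N(c1cccc(F)c1)C1CCCC1N(C)C`) gives the lowest number of them at 0.6 mg/kg for the effect. Against it, compound 3 (`CCC(=O)N(c1ccc(Br)cc1)C1CCCC1N(C)C`) reads 3 mg/kg and compound 1 (`CCC(=O)N(c1ccccc1C)C1CCCC1N(C)C`) reads 5 mg/kg with both numbers clearly higher.

The next member, compound 4 (`CCC(=O)N(c1cccc(C(F)(F)F)c1)C1CCCC1N(C)C`), keeps all of compound 2 except one group: trifluoromethyl takes the place of fluoro on an aromatic carbon (trifluoromethyl in place of fluoro on an aromatic carbon). Among the compounds with values here, no measured pair isolates this exchange, so the size of the step can only be judged from the spread of the three numbers. Compound 2 at 0.6 mg/kg sits at the low end of that spread, and the two other compounds, which carry different groups on the ring, both give higher numbers. A moderate step to a higher number in this assay is therefore expected, lying a little beyond the scatter, though with little evidence behind it. The estimate amounts to a 2.5-fold higher number from compound 2 to compound 4 (0.40 log units; beyond the scatter) as the expected change. For compound 4 the estimated dose is 1.5 mg/kg with a range from 0.4 mg/kg to 6 mg/kg expected to hold the measurement.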

Compound 4, dose for half-maximal effect: 0.2 mg/kg
Beside the measured number, compound 4's estimate is 7.5-fold (0.88 log units) above it; the measured number lies below the stated range.
By their numbers in this assay, from the lowest: compound 4; then compound 2; then compounds 3 and 1 (each within the scatter of the next).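

Within the data shown here, the exchange gives the first step in this assay that isolates a single group: with trifluoromethyl in place of fluoro on an aromatic carbon, meta to a large group, the result is a 3.0-fold lower number from compound 2 to compound 4 (0.48 log units; beyond the scatter) and this modest step lies beyond the scatter. It shows that this place on the ring tolerates trifluoromethyl, with 4 heavy atoms, where fluoro has 1 heavy atom, and that the larger group goes with the lower number here, so less compound is needed for the effect. This single pair gives the direction and size of the change, but no measured property of either compound bears on the reason for it.

With only fluoro and trifluoromethyl compared at this place, the compounds shown leave open whether the trend continues with other groups there, such as chloro, methoxy, nitrile or a longer chain such as ethyl. They also leave open whether trifluoromethyl would give a similar step at another carbon of the ring, or whether a second group on the ring would add to it.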